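A few compounds are considered here, and "the series" means these few. Any claim that something is new, unique, unknown or untested is made for them only; others in the source may bear on it.

Working notes on the series built on the shared core of compound 1 `O=C(CCC1=CCN(CCCc2ccc(Br)cc2)C1=O)NO`. In a functional assay on HCT-15 cells (Homo sapiens) for inhibition, read by sulforhodamine B assay (a lower number here means a stronger inhibitor of growth, a higher number a weaker inhibitor of growth), compound 1 gives 5100 nM. Compound 2 `O=C(CCC1=CCN(CCCc2ccc(Cl)cc2)C1=O)NO` carries chloro in place of bromo on an aromatic carbon, and in this assay compound 2 gives 5100 nM. Among the compounds with values here, the step of no change at the digits printed from compound 1 to compound 2 (within the scatter) is the only measured step in the set, so compound 2 stands level with compound 1 at the digits printed, with no change between them beyond the scatter.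

Compound 3 `Cc1ccccc1CCCN1CC=C(CCC(=O)NO)C1=O` is the next member. Its difference from compound 2 is 2-methylphenyl in place of 4-chlorophenyl on a saturated chain carbon, three bonds along the chain from an amide-type nitrogen in a ring. Within the data shown here, the single measured step bears on it only loosely: it swapped one halogen for another on the aromatic carbon and left the number unchanged, whereas the change to compound 3 replaces the whole 4-chlorophenyl with 2-methylphenyl, a change for which no measured step exists. With only an unchanged halogen swap to go on, no step beyond the scatter is expected in this assay in either direction, and the range is kept wide. Compound 3 is therefore estimated at 5500 nM, between 2000 nM and 15000 nM, an expected step of a 1.1-fold higher number from compound 2 to compound 3 (0.03 log units; within the scatter).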

Compound 3, concentration for 50% growth inhibition: 5100 nM
For compound 3 the middle estimate is 1.1-fold (0.03 log units) above the measured one, within the range that was stated.
By their numbers in this assay, from the lowest: compounds 1, 2 and 3 (each within the scatter of the next).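

In this assay, replacing the whole 4-chlorophenyl with 2-methylphenyl on a saturated chain carbon, three bonds along the chain from an amide-type nitrogen in a ring, gives no change at the digits printed from compound 2 to compound 3 (within the scatter) and the matching change from 4-bromophenyl gives no change at the digits printed from compound 1 to compound 3 (within the scatter) as well. The earlier step exchanged one halogen for another, whereas these two steps show that this position also accepts a carbon-only 2-methylphenyl with no halogen on the ring, with the number staying within the scatter. No available evidence accounts for this flat response.

The change from 4-chlorophenyl to 2-methylphenyl alters both the substituent and its place on the ring, so the compounds shown cannot separate those two contributions; 4-methylphenyl and 2-chlorophenyl would be the direct comparisons. Also open, going by these compounds, is whether the number stays level when the position carries a group of a different kind, such as an unsubstituted phenyl, a phenyl bearing an amine or a carboxylic acid, or a longer chain leading to the ring.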